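The compounds below may be only part of what the source reports. "The series", "measured", "known", "first", "only" and "open" are said of these compounds alone.

Measured compounds:
compound 1 `COc1ccc(/C=C/C(=O)OC[C@@H](OCc2ccccc2)[C@H]2OC(=O)C=C[C@H]2OCc2ccccc2)cc1` — 690 nM
compound 2 `O=C1C=C[C@@H](OCc2ccccc2)[C@@H]([C@@H](COC(=O)/C=C/c2ccc(F)cc2)OCc2ccccc2)O1` — 2470 nM

In a functional assay on Raji cells (Homo sapiens) for antiproliferative activity, read by MTT assay, with a stated time of 6 days (on this read-out lower numbers stand for stronger inhibition and higher numbers for weaker inhibition), compound 2 gives 2470 nM, the highest of the two numbers recorded so far; the nearest is compound 1, which gives 690 nM. Among the compounds with values here, the one step within the set is a 3.6-fold higher number from compound 1 to compound 2 (0.55 log units; beyond the scatter), the sole change being on the aromatic ring of the cinnamate ester.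

Compound 3 `O=C1C=C[C@@H](OCc2ccccc2)[C@@H]([C@@H](COC(=O)/C=C/c2ccc([N+](=O)[O-])cc2)OCc2ccccc2)O1` differs from compound 2 at that same place: nitro in place of fluoro on an aromatic carbon, on an aromatic carbon of a six-membered aromatic ring of carbon only, para to a large group.

Within the data shown here, only the step from compound 1 to compound 2 bears on this change, and it touched the same ring position, with methoxy leaving and fluoro entering. Among the measured compounds shown here, no measured step covers nitro itself. For the measured compounds named here, the one step seen at this position was modest, so a modest step is expected for compound 3 as well, with the direction open; the estimate sits near compound 2 with a wide range, expressed as a 1.1-fold lower number from compound 2 to compound 3 (0.05 log units; within the scatter).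

Compound 3 is thus expected at 2200 nM, with a range from 800 nM to 6000 nM.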

Compound 3, half-maximal inhibitory concentration: 140 nM
The estimate for compound 3 lay 16-fold (1.20 log units) above the measured number; the measured number lies below the stated range.
By their numbers in this assay, from the lowest: compound 3; then compound 1; then compound 2.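

In this assay, fluoro and nitro at this position on the aromatic ring give an 18-fold lower number from compound 2 to compound 3 (1.25 log units; beyond the scatter), showing that a single exchange here can produce a large step, well beyond the modest one seen earlier, a 3.6-fold higher number from compound 1 to compound 2 (0.55 log units; beyond the scatter). Nitro in place of methoxy gives a 4.9-fold lower number from compound 1 to compound 3 (0.69 log units; beyond the scatter), so all three groups are now separated beyond the scatter: nitro gives the lowest number, methoxy the middle one and fluoro the highest. No measurement on hand accounts for this order or for the size of the step.

Three groups at one position cannot show how the number would respond to others at the same place, such as an amine, a carboxylic acid or a nitrile, or whether any of these would fall below the number for nitro. From the compounds shown here alone, it also remains open whether the order of nitro, methoxy and fluoro would hold if the benzyl ethers on the shared core were replaced, for example by a longer chain.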